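This account rests on a few compounds, and the source may have more. Where it says the series, first, only, none or still open, it means among the compounds named here.

Compound 1 `C(=N/Nc1nc2ccccc2nc1Cc1ccccc1)\c1ccccc1`: 320000 nM
Compound 2 `C/C(=N\Nc1nc2ccccc2nc1Cc1ccccc1)c1ccc(C)cc1`: 740000 nM
Compound 3 `C/C(=N\Nc1nc2ccccc2nc1Cc1ccccc1)c1ccc(N)cc1`: 860000 nM

All three were tested in an assay on isolated protein for inhibition of Amine oxidase [flavin-containing] B (Homo sapiens), read by spectrophotometry; a higher number here means a weaker inhibitor, a lower number a stronger inhibitor. Compound 1 gives the lowest of the three numbers; compound 2 and compound 3 both sit beyond the scatter above it. Compound 4 `O=[N+]([O-])c1ccc(/C=N/Nc2nc3ccccc3nc2Cc2ccccc2)cc1` differs from compound 1 by nitro in place of hydrogen on an aromatic carbon. For the measured compounds named here, the only measured step that alters a group on that ring, a 1.2-fold higher number from compound 2 to compound 3 (0.07 log units; within the scatter), was within the scatter, but it swapped one group for another rather than adding one to a bare position, so it bears only loosely on this change. Going by the values given here, no measured step adds a nitro group. The expected step, a 1.3-fold lower number from compound 1 to compound 4 (0.11 log units; within the scatter), is therefore small and uncertain, with a slight lean toward a lower number. Compound 4 is estimated at 250000 nM, between 80000 nM and 800000 nM.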

Compound 4, half-maximal inhibitory concentration: 960000 nM
Compound 4: the middle estimate sits 3.8-fold (0.58 log units) below what was measured; the measured number lies above the stated range.
By their numbers in this assay, from the lowest: compound 1; then compounds 2, 3 and 4 (each within the scatter of the next).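

Going from phenyl to 4-nitrophenyl gives a 3.0-fold higher number from compound 1 to compound 4 (0.48 log units; beyond the scatter) in this assay and so makes compound 4 the weaker inhibitor. For the compounds shown here, this is the first single change here that lies beyond the scatter, which shows that this place on the ring does respond to a substituent and that nitro para to a large group costs some inhibition. The data offer no measurement that accounts for this step.

As far as these compounds go, whether fluorine, methoxy or an amine at the same place on compound 1 would also raise the number remains open. So does whether nitro at another place on the ring would have the same effect.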